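The source may hold more compounds than are shown below. What is called first, only, known or untested is meant among the compounds shown, and "the series" means these compounds.

Compound 1 `CCc1cc(C(C)=O)c(O)cc1OCCCCCCC#N` carries an ethyl group, an acetyl group and a free hydroxy on its core, with an ether chain ending in a nitrile. Going by the values given here, in an assay on isolated protein for inhibition of leukotriene B4 receptor 1 (Homo sapiens), tested at 10 uM (on this read-out lower numbers stand for less inhibition and higher numbers for more inhibition at the one concentration tested (going by the name of the read-out)), compound 1 gives 103%, the higher of the two numbers measured so far. Its nearest companion is compound 2 `CC(=O)c1cc(CO)c(OCCCCCCC#N)cc1O`, which in this assay gives 40%; the difference between them is a number 63 percentage points lower from compound 1 to compound 2 (beyond the scatter), a change made at a different place from the one considered here. Compound 3 `CCc1cc(C(C)=O)c(O)cc1OCCCCCC(C)(C)C(=O)O` has not yet been tested. The change from compound 1 to compound 3 is 1-carboxy-1-methylethyl in place of cyanomethyl on a saturated chain carbon, five bonds along the chain from an oxygen on an aromatic ring. Among the compounds with values here, no measured step touches the end of the ether chain, so the one measured step offers no direct guide to this change. The number for compound 1 is already the higher of the two measured, leaving little room above it. For compound 3 the expected value in this assay is 90%, with a range from 55% to 105%. This corresponds to an expected step of a number 13 percentage points lower from compound 1 to compound 3 (beyond the scatter), which is likely to stay within the scatter.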

Compound 3, a percentage reported as inhibition, at one concentration (the size of the read-out at that concentration, not a potency): 104%
Beside the measured number, compound 3's estimate is 14 percentage points below it, and the stated range covers the measured number.
By their numbers in this assay, from the lowest: compound 2; then compounds 1 and 3 (each within the scatter of the next).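

In this assay, going by these compounds alone, the first measured change at this place, on a saturated chain carbon five bonds along the chain from an oxygen on an aromatic ring, gives a number 1 percentage points higher from compound 1 to compound 3 (within the scatter) when 1-carboxy-1-methylethyl replaces cyanomethyl. The earlier step, with hydroxy in place of methyl, lay elsewhere on the molecule, so only this result shows that the read-out at this one concentration holds when the six heavy atoms of the entering group, with a carboxy group in place of a nitrile, replace the three of the leaving group. The data offer no measured explanation for why the number holds through this change.

From the compounds shown here alone, whether an amine or a primary amide at the same place would give a similar number remains open, as does the effect of a plain carboxymethyl group without the two methyl groups or of a longer chain. Going by these compounds, both compounds were read at a single concentration, so any difference in potency between them also remains open.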